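From Sulfonyl to Formyl on the Shared Core

The compounds below may be only part of what the source reports. "The series", "measured", "known", "first", "only" and "open" are said of these compounds alone.

In a functional assay on HeLa cells (Homo sapiens) for antiproliferative activity, with a stated time of 48 h (on this read-out higher numbers stand for weaker inhibition and lower numbers for stronger inhibition), compound 2 (`Cc1ccc(S(=O)(=O)N2c3c(N)nc(N)nc3CCC2CN(C)c2ccc(C(=O)N[C@@H](CCC(=O)O)C(=O)O)cc2)cc1`) gives 434 nM and compound 1 (`C=CCN1c2c(N)nc(N)nc2CCC1CN(C)c1ccc(C(=O)N[C@@H](CCC(=O)O)C(=O)O)cc1`) gives 227 nM so the two cannot be told apart. Compound 3 (`CN(CC1CCc2nc(N)nc(N)c2N1C=O)c1ccc(C(=O)N[C@@H](CCC(=O)O)C(=O)O)cc1`) differs from compound 2 by formyl in place of (4-methylphenyl)sulfonyl on a nitrogen on an aromatic ring in a ring. For the measured compounds named here, one measured step bears on this nitrogen: a 1.9-fold higher number from compound 1 to compound 2 (0.28 log units; within the scatter) for (4-methylphenyl)sulfonyl in place of allyl. Going by the values given here, no formyl compound has been measured, so the range stays wide, and no step beyond the scatter is expected in this assay here. The estimate is an expected 1.4-fold lower number from compound 2 to compound 3 (0.16 log units; within the scatter) in this series. Compound 3 is estimated at 300 nM (100 nM to 900 nM).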

Compound 3, half-maximal inhibitory concentration: 6000 nM
For compound 3 the middle estimate is 20-fold (1.30 log units) below the measured one; measured number outside the range, above it.
By their numbers in this assay, from the lowest: compounds 1 and 2 (each within the scatter of the next); then compound 3.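

In this assay this nitrogen proves sensitive to its substituent, which the first pair could not reveal: formyl gives a 14-fold higher number from compound 2 to compound 3 (1.14 log units; beyond the scatter) and a 26-fold higher number from compound 1 to compound 3 (1.42 log units; beyond the scatter). Allyl and (4-methylphenyl)sulfonyl are very different groups yet stay within the scatter of each other, so among these three compounds only formyl stands apart. No measurement shown here accounts for this loss of inhibition. The compounds shown leave open whether an acetyl or a methyl group on this nitrogen would stay with compound 1 and compound 2 or fall with compound 3.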